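The source may hold more compounds than are shown below. What is called first, only, known or untested is meant among the compounds shown, and "the series" means these compounds.

Measured so far:
compound 1, `CC(C)OC(=O)N1CCC(Oc2ncnc3c2CCN3c2ccc(S(C)(=O)=O)nc2)CC1`, gives 97% in a functional assay on CHO-K1 cells with Glucose-dependent insulinotropic receptor (Homo sapiens) as the target, read by a luciferase reporter, with a stated time of 5 h; on this read-out lower numbers stand for smaller maximal responses and higher numbers for larger maximal responses
compound 2, `CC(C)OC(=O)N1CCC(Oc2ncnc3c2CCN3c2ccc(C#N)c(F)c2)CC1`, gives 121%

Compound 2 stands highest of the two numbers. For the measured compounds named here, the only measured step, a number 24 percentage points higher from compound 1 to compound 2 (beyond the scatter), exchanges the whole ring on the nitrogen and so bears only loosely on what follows. Compound 3, `CSc1ccc(N2CCc3c(OC4CCN(C(=O)OC(C)C)CC4)ncnc32)cc1F`, differs from compound 2 in one place: methylsulfanyl in place of cyano on an aromatic carbon. Going by the values given here, no measured pair alters a single substituent on that ring, so the expected step is a number 11 percentage points lower from compound 2 to compound 3 (beyond the scatter), within the scatter with a slight downward lean. Compound 3 is therefore estimated at 110%, in the range 85% to 130%.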

Compound 3, largest response reached (reported as percent of maximum), in percent of the reference or control that the assay uses: 121%
Compound 3: middle estimate off by 11 percentage points, on the low side, and the stated range covers the measured number.
By their numbers in this assay, from the lowest: compound 1; then compounds 2 and 3 (each within the scatter of the next).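

In this assay, methylsulfanyl in place of cyano on the aromatic carbon ortho to a fluoro group gives no change at the digits printed from compound 2 to compound 3 (within the scatter), so the cyano group is not needed there to keep this maximal response. The exchange of the whole ring on the nitrogen now gives a number 24 percentage points higher from compound 1 to compound 3 (beyond the scatter), matching the earlier step with a second substituent on the fluorinated ring. Nothing available explains why the two groups read alike. As far as these compounds go, whether an amine, a carboxylic acid or a longer chain on this carbon would read the same remains open.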